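Isopropyl to propyl on the fused ring of compound 3

This account rests on a few compounds, and the source may have more. Where it says the series, first, only, none or still open, it means among the compounds named here.

Three compounds share one core and differ only in a single group on the six-membered carbon ring of the fused system. Compound 1 `Cc1c(C(=O)Nc2ccc(Oc3ncnc4[nH]cc(-c5ccccc5)c34)c(F)c2)c(=O)c2cc(F)ccc2n1C` carries fluoro there, compound 2 `Cc1c(C(=O)Nc2ccc(Oc3ncnc4[nH]cc(-c5ccccc5)c34)c(F)c2)c(=O)c2cc(C(F)(F)F)ccc2n1C` trifluoromethyl, and compound 3 `Cc1c(C(=O)Nc2ccc(Oc3ncnc4[nH]cc(-c5ccccc5)c34)c(F)c2)c(=O)c2cc(C(C)C)ccc2n1C` isopropyl. In an assay on isolated protein for inhibition of tyrosine-protein kinase receptor UFO (Homo sapiens), read by FRET and Z'-LYTE, with a stated time of 1.5 h (a lower number here means a stronger inhibitor, a higher number a weaker inhibitor), compound 1 reaches only a limit of the assay, > 10000 nM. In this assay compound 2 gives 150 nM, and compound 3 gives 26 nM. The step of an at least 66-fold lower number from compound 1 to compound 2 (1.82 log units; beyond the scatter) and the step of an at least 380-fold lower number from compound 1 to compound 3 (2.58 log units; beyond the scatter) are both large, though each starts from a limit, (the limit of > 10000 nM in this assay, at which 1 of the 3 values shown sits). The step of a 5.8-fold lower number from compound 2 to compound 3 (0.76 log units; beyond the scatter) is modest. Compound 3 therefore stands at the lowest number shown, with compound 2 the nearest and compound 1 known only as a limit.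

Compound 4 `CCCc1ccc2c(c1)c(=O)c(C(=O)Nc1ccc(Oc3ncnc4[nH]cc(-c5ccccc5)c34)c(F)c1)c(C)n2C` is the next member: propyl in place of isopropyl on an aromatic carbon. The three-carbon group keeps its size and its place; only its branching changes. Within the data shown here, no measured step addresses branching of an alkyl group, so the nearest guide is the modest size of the step of a 5.8-fold lower number from compound 2 to compound 3 (0.76 log units; beyond the scatter) between two groups of similar bulk. A change of at most modest size is expected, a 1.5-fold higher number from compound 3 to compound 4 (0.19 log units; within the scatter), with a weakening somewhat more likely than a gain. The estimate for compound 4 in this assay is 40 nM, within a range from 12 nM to 130 nM.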

Compound 4, half-maximal inhibitory concentration: 61 nM
Estimate against measurement, compound 4: 1.5-fold (0.18 log units) below; the range from low to high includes it.
By their numbers in this assay, from the lowest: compound 3; then compound 4; then compound 2. At a limit, above all of these: compound 1.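

In this assay, among these compounds, a 2.3-fold higher number from compound 3 to compound 4 (0.37 log units; beyond the scatter) is modest but beyond the scatter, so at this position the arrangement of the same three carbons is enough to move the number, something the earlier compounds could not show because their groups differed in their atoms: the limit of > 10000 nM in this assay, at which 1 of the 4 values shown sits. Propyl still keeps the advantage over trifluoromethyl, with a 2.5-fold lower number from compound 2 to compound 4 (0.39 log units; beyond the scatter), which places the unbranched chain between the two groups measured earlier and shows that the gain over trifluoromethyl does not depend on branching alone. Among the compounds shown here, the step of an at least 160-fold lower number from compound 1 to compound 4 (2.21 log units; beyond the scatter) is large, and like the earlier steps from compound 1 it starts from a limit, so it gives only a floor for how far propyl stands from fluoro.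

The compounds shown do not tell how a tert-butyl group, a cyclopropyl ring or a longer chain such as butyl would stand at this position, or whether any of them would go lower than isopropyl. They also leave open where a chloro or a methoxy group would fall in the wide span between fluoro and the three-carbon groups.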